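A Smaller Group in Place of a Larger One

The source may report more compounds than this note shows. Statements on the series, on what has been measured and on what is new or still open speak of the compounds shown alone.

Compound 1 `COc1ccc(N(C)c2nc(C)nc3ccccc23)cc1C(=O)OCCCC[Se]C#N`: 975 nM
Compound 2 `COc1ccc(N(C)c2nc(C)nc3ccccc23)cc1C(=O)OCCCCCC[Se]C#N`: 2650 nM

In a functional assay on HepG2 cells (Homo sapiens) for inhibition, read by MTT assay, with a stated time of 48 h (on this read-out higher numbers stand for weaker inhibition and lower numbers for stronger inhibition), compound 1 gives 975 nM, the lower of the two numbers and so the stronger inhibition. Compound 3 `COc1ccc(N(C)c2nc(C)nc3ccccc23)cc1OCCN`, not yet measured, keeps the core of compound 1 but changes one side group: a group of 4 heavy atoms (2 carbon, 1 nitrogen, 1 oxygen; no ring) in place of a group of 10 heavy atoms (6 carbon, 1 nitrogen, 2 oxygen, 1 selenium; no ring), on an aromatic carbon. The group that enters is 2-aminoethoxy. Going by the values given here, only one measured step bears on this, and only loosely: a 2.7-fold higher number from compound 1 to compound 2 (0.43 log units; beyond the scatter). There, the larger group came with the higher number. The present change goes further. Among the compounds with values here, the selenium-containing group leaves entirely, and no measured compound shows what that alone does. A modest move towards a lower number is the best expectation, though an uncertain one, and a move the other way remains possible. The expected step is a 2.0-fold lower number from compound 1 to compound 3 (0.29 log units; within the scatter). Compound 3 is estimated at 500 nM, with an expected range from 60 nM to 4000 nM.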

Compound 3, half-maximal inhibitory concentration: 343 nM
Estimate against measurement, compound 3: 1.5-fold (0.16 log units) above; the measured number falls inside the stated range.
By their numbers in this assay, from the lowest: compound 3; then compound 1; then compound 2.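

Compound 3 shows that this position on the aromatic ring does not need the group of 10 heavy atoms that carries selenium: with 2-aminoethoxy there instead, this assay gives a 2.8-fold lower number from compound 1 to compound 3 (0.45 log units; beyond the scatter). Going by these compounds alone, both earlier compounds carried selenium, so this is the first sign that inhibition on this core can persist without it. Nothing at hand says what lies behind this step.

The whole side group changes at once, so the step cannot separate the part played by the selenium from that of the chain or the carbonyl group. Also open, from the compounds shown here alone, is whether the amine itself matters, which a 2-hydroxyethoxy group in the same place could test, and how a longer chain ending in an amine would compare.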